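The source may hold more compounds than are shown below. What is called first, only, known or untested is meant among the compounds shown, and "the series" means these compounds.

Measured so far:
compound 1, `CN1CCC(n2cc(S(=O)(=O)c3ccccc3F)c3cccnc32)C1`, 69%
compound 2, `CN1CCC(n2cc(S(=O)(=O)c3ccccc3Cl)c3cccnc32)C1`, 91%
compound 3, `CCN1CCC(n2cc(S(=O)(=O)c3cccc(F)c3)c3cccnc32)C1`, 89%

All three were tested in a functional assay on HeLa cells for antagonist activity at 5-hydroxytryptamine receptor 6 (Homo sapiens), read by cAMP accumulation and immunoassay; a higher number here means a larger maximal response, a lower number a smaller maximal response. Within the data shown here, compound 1 is the weakest of the three, and the only change that has a measured step here is the one from compound 1 to compound 2: chloro in place of fluoro on an aromatic carbon. That step was a number 22 percentage points higher from compound 1 to compound 2 (beyond the scatter). Compound 3 has a different core from compound 1 and compound 2; how the two cores differ is not broken down here. Its value stands within the scatter of compound 2, so no order can be read between those two, while compound 1 gives a clearly lower number than compound 3.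

Compound 4, `CCN1CCC(n2cc(S(=O)(=O)c3cccc(Cl)c3)c3cccnc32)C1`, has not yet been measured. It differs from compound 3 by chloro in place of fluoro on an aromatic carbon. Among the measured compounds shown here, this is the same kind of change as the one from compound 1 to compound 2, but not the same: in compound 1 the fluoro sits ortho to a large group, in compound 3 it sits meta to a large group.

For the measured compounds named here, the earlier step gives the only guide. Because compound 3 already gives 89%, there is less room to climb, so a smaller step than the earlier one is expected: an estimated a number 6 percentage points higher from compound 3 to compound 4 (within the scatter). Compound 4 is therefore expected to reach about 95% in this assay, with an estimated range from 85% to 105%.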

Compound 4, largest response reached (reported as percent of maximum), in percent of the reference or control that the assay uses: 93%
Beside the measured number, compound 4's estimate is 2 percentage points above it, within the range that was stated.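

In this assay, putting chloro in place of fluoro gave a number 4 percentage points higher from compound 3 to compound 4 (within the scatter), so on this core the swap produces no change that can be told apart from the ordinary spread of repeated measurements. The same swap therefore does not carry over from one core to the other at the same size: the same change on two cores in this assay, a number 22 percentage points higher (beyond the scatter) from compound 1 to compound 2 and a number 4 percentage points higher (within the scatter) from compound 3 to compound 4, 18 percentage points apart, beyond the scatter of two such steps

This shows that a step seen on one core cannot simply be added to another in this series, but it does not show that the core alone sets the size of the step, as the two pairs also differ in where the halogen sits on the aromatic ring and in their starting values, with compound 1 at 69% and compound 3 at 89%.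

The compounds shown leave open how a group other than these two halogens, such as a methoxy or a nitrile, would behave when meta to a large group. They also leave open whether a longer chain, such as propyl, on the nitrogen of the saturated ring would alter the effect of the swap from fluoro to chloro.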